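This account rests on a few compounds, and the source may have more. Where it says the series, first, only, none or still open, it means among the compounds named here.

Measured so far in a functional assay on JeKo-1 cells (Homo sapiens) for antiproliferative activity; a lower number here means a stronger inhibitor, a higher number a weaker inhibitor:

Compound 1 `Nc1ncnc2c1c(-c1ccc(Oc3ccccc3)cc1)cn2C[C@H]1CCCN1C[C@@H](O)CO`: 9540 nM
Compound 2 `Nc1ncnc2c1c(-c1cc3ccccc3o1)cn2[C@H]1CCN(C[C@@H]2CO2)C1`: 2820 nM

Of these two numbers, compound 1 has the higher one, which makes it the weaker inhibitor of the pair, and its gap to compound 2 lies beyond the usual scatter. Compound 3 `Nc1ncnc2c1c(-c1ccc(Oc3ccccc3)cc1)cn2C[C@H]1CCCN1C(CO)CO` is built from the same atoms as compound 1, joined differently: 2-hydroxy-1-(hydroxymethyl)ethyl stands in place of 2,3-dihydroxypropyl on an amine nitrogen in a ring (2-hydroxy-1-(hydroxymethyl)ethyl in place of 2,3-dihydroxypropyl on an amine nitrogen in a ring). Among the measured compounds shown here, no measured pair shows what this kind of change does. In this assay, then, no step beyond the scatter is expected in either direction, and the starting point remains compound 1 at 9540 nM. The estimate amounts to a 1.0-fold higher number from compound 1 to compound 3 (0.02 log units; within the scatter). Compound 3 is expected at about 10000 nM, with an estimated range from 4000 nM to 25000 nM.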

Compound 3, half-maximal inhibitory concentration: 14500 nM
Compound 3: middle estimate off by 1.5-fold (0.16 log units), on the low side; low and high end bracket the measured number.
By their numbers in this assay, from the lowest: compound 2; then compounds 1 and 3 (each within the scatter of the next).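

In this assay, among the compounds shown here, the swap of 2,3-dihydroxypropyl for 2-hydroxy-1-(hydroxymethyl)ethyl on the amine nitrogen of the five-membered ring gives a 1.5-fold higher number from compound 1 to compound 3 (0.18 log units; within the scatter) and is the first measured reading of this kind of change. With the same atoms joined differently, the two side chains cannot be told apart in this test, even though the defined stereocentre of 2,3-dihydroxypropyl is gone. Nothing measured here explains the result. As far as these compounds go, what stays open is whether a different kind of group on this nitrogen, such as a carboxylic acid or a longer chain like 4-hydroxybutyl, would give a step beyond the scatter. From the compounds shown here alone, the mirror-image form of 2,3-dihydroxypropyl also remains open.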